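This account rests on a few compounds, and the source may have more. Where it says the series, first, only, none or still open, it means among the compounds named here.

Measured compounds: compound 1 `COc1cc(OC)c(/C=C(/SCc2ccc(F)cc2)C(=O)c2ccc(Cl)cc2)c(OC)c1`, 10000 nM; compound 2 `COc1cc(OC)c(/C=C(/SCc2ccc(Cl)cc2Cl)C(=O)c2ccc(Cl)cc2)c(OC)c1`, 1000 nM; compound 3 `COc1cc(OC)c(/C=C(\C(=O)c2ccc(Cl)cc2)S(=O)(=O)c2ccc(C)cc2)c(OC)c1`, 25000 nM.

In a functional assay on DU-145 cells (Homo sapiens) for inhibition, read by trypan blue exclusion, with a stated time of 96 h (on this read-out higher numbers stand for weaker inhibition of growth and lower numbers for stronger inhibition of growth), compound 1 holds the second highest of the three numbers; the nearest number is found by a 2.5-fold higher number from compound 1 to compound 3 (0.40 log units; beyond the scatter) and the furthest by a 10-fold lower number from compound 1 to compound 2 (1.00 log units; beyond the scatter). Compound 4 `COc1cc(OC)c(/C=C(/SCc2ccc(F)cc2)C(=O)c2ccc(Br)cc2)c(OC)c1` differs from compound 1 by bromo in place of chloro on an aromatic carbon. Both measured steps alter the group on the sulfur and leave the ring bound to the carbonyl untouched, so neither bears directly on this halogen swap, and nothing measured speaks to it. The account therefore expects no step beyond the scatter, with a 1.3-fold lower number from compound 1 to compound 4 (0.10 log units; within the scatter). Compound 4 is estimated at 8000 nM, within 3000 nM to 25000 nM.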

Compound 4, concentration for 50% growth inhibition: 1000 nM
The estimate for compound 4 lay 8.0-fold (0.90 log units) above the measured number, and the stated range ends above it.
By their numbers in this assay, from the lowest: compounds 2 and 4 (each within the scatter of the next); then compound 1; then compound 3.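

In this assay, for the compounds shown here, the change from 4-chlorophenyl to 4-bromophenyl gives a 10-fold lower number from compound 1 to compound 4 (1.00 log units; beyond the scatter) on the side of the carbonyl, so a single halogen swap at this position, which no earlier step touched, moves the number beyond the scatter. This step matches in printed size a 10-fold lower number from compound 1 to compound 2 (1.00 log units; beyond the scatter) on the group on the sulfur, so both sides of compound 1 respond to change. Nothing available explains why bromo differs from chloro here. From the compounds shown here alone, whether the swap holds with the 2,4-dichlorobenzyl group on the sulfur remains open, as does how a methoxy group or an amine would read in this place.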